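Fluoro for Methyl on the Benzimidazole of a Somatostatin Agonist

The source may report more compounds than this note shows. Statements on the series, on what has been measured and on what is new or still open speak of the compounds shown alone.

Compound 3 `Cc1cc(C)cc(-c2cncc(-c3nc4cc(C)ccc4[nH]3)c2N2CCC(N)CC2)c1` gives 0.013 nM in a functional assay on CHO-K1 cells for agonist activity at somatostatin receptor type 2 (Homo sapiens), read by cAMP accumulation, with a stated time of 30 min (a higher number here means that more compound is needed for the effect, a lower number that less compound is needed), the lowest of the three numbers measured. Compound 1 `Cc1cc(F)cc(-c2cncc(-c3nc4cc(F)ccc4[nH]3)c2N2CCC(N)CC2)c1` stands close to it with 0.019 nM, a gap within the scatter. Compound 2 `Cc1cc(C)cc(CNc2cncc(-c3cc(C)cc(C)c3)c2N2CCC(N)CC2)c1` gives 0.8 nM. For the measured compounds named here, the only measured step, a 62-fold lower number from compound 2 to compound 3 (1.79 log units; beyond the scatter), is large but concerns another part of the molecule. Compound 4 `Cc1cc(C)cc(-c2cncc(-c3nc4cc(F)ccc4[nH]3)c2N2CCC(N)CC2)c1` differs from compound 3 by fluoro in place of methyl on an aromatic carbon. Going by the values given here, no measured step isolates this change; still, compound 1, which carries the same fluoro group, and compound 3 lie within the scatter of each other, so little movement in this assay is expected. For compound 4 the estimate is 0.016 nM, between 0.007 nM and 0.04 nM. The expected step is a 1.2-fold higher number from compound 3 to compound 4 (0.09 log units; within the scatter).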

Compound 4, half-maximal effective concentration: 0.013 nM
Compound 4: the middle estimate sits 1.2-fold (0.09 log units) above what was measured, within the range that was stated.
By their numbers in this assay, from the lowest: compounds 3, 4 and 1 (each within the scatter of the next); then compound 2.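

In this assay, fluoro in place of methyl at this position of the benzimidazole now has a step of its own, no change at the digits printed from compound 3 to compound 4 (within the scatter), and methyl in place of fluoro on another aromatic carbon gives a 1.5-fold lower number from compound 1 to compound 4 (0.16 log units; within the scatter). The large gain over the (3,5-dimethylbenzyl)amino group also holds with the 5-fluoro-1H-benzimidazol-2-yl group, at a 62-fold lower number from compound 2 to compound 4 (1.79 log units; beyond the scatter). No supporting evidence bears on this result. As far as these compounds go, how this position would respond to a methoxy group, an amine or a carboxylic acid remains open.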